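Swapping a Fluorinated Ring for a Brominated One

This account rests on a few compounds, and the source may have more. Where it says the series, first, only, none or still open, it means among the compounds named here.

Compound 1 `Fc1ccc(Nc2nc(-c3cccc(F)c3)nc3ccc(F)cc23)cc1` and compound 2 `Fc1cccc(-c2nc(Nc3ccccc3F)c3cc(F)ccc3n2)c1` share one core and differ only in the ring carried on a nitrogen on an aromatic ring. In a functional assay on U2OS cells (Homo sapiens) for cytotoxicity, read by MTT assay, with a stated time of 48 h (on this read-out higher numbers stand for weaker inhibition and lower numbers for stronger inhibition), compound 1 reaches only the limit of the assay, > 50000 nM. In this assay compound 2 likewise reaches only the limit, > 50000 nM. The step that the two limits leave unreadable from compound 1 to compound 2 therefore cannot be read, because both ends sit at the limit (the limit of > 50000 nM in this assay, at which 2 of the 2 values shown sit). Compound 3 `Fc1cccc(-c2nc(Nc3cccc(Br)c3)c3cc(F)ccc3n2)c1` has not been measured; it differs from compound 2 by 3-bromophenyl in place of 2-fluorophenyl on a nitrogen on an aromatic ring. For the measured compounds named here, the only measured step, from compound 1 to compound 2, gives neither sign nor size, so nothing about the coming change can be taken from it. Compound 3 is accordingly expected to remain near the limit, with a step of a number no higher from compound 2 to compound 3 (the limit leaves the size open) being no more than a cautious guess. The estimate for compound 3 in this assay is 50000 nM, ranging from 10000 nM to 150000 nM.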

Compound 3, half-maximal inhibitory concentration: > 50000 nM
Compound 3: no number, only a limit; the forecaster's own chance of this, stated with the estimate: 70%; the middle value sits exactly at the limit.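

In this assay, for the compounds shown here, compound 3 also gives only a limit, so no step among compound 1, compound 2 and compound 3 can be read: the limit of > 50000 nM in this assay, at which 3 of the 3 values shown sit. These compounds leave open whether changing the ring on the nitrogen alters cytotoxicity at all, and by how much.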